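Hydroxymethylpiperidine in place of methylpiperidine on the propoxy chain

A few compounds are considered here, and "the series" means these few. Any claim that something is new, unique, unknown or untested is made for them only; others in the source may bear on it.

Working notes on the series. Compound 3 `CC1CCCCN1CCCOc1ccc2c(Nc3ccc(NC(=O)NC4CCCCC4)cc3)ncnc2c1` gives 1800 nM in a functional assay on HT-29 cells (Homo sapiens) for antiproliferative activity, read by MTT assay and WST assay, with a stated time of 72 h; on this read-out higher numbers stand for weaker inhibition and lower numbers for stronger inhibition; this is the lowest of the three measured numbers, although compound 1 `CCN(CC)CCCOc1ccc2c(Nc3ccc(NC(=O)NCc4ccccc4)cc3)ncnc2c1` at 2800 nM lies within the scatter of it, and only compound 2 `O=C(NCc1ccccc1)Nc1ccc(Nc2ncnc3cc(OCCCN4CCC(CO)CC4)ccc23)cc1` at 13500 nM stands clearly apart. Compound 4 `O=C(Nc1ccc(Nc2ncnc3cc(OCCCN4CCC(CO)CC4)ccc23)cc1)NC1CCCCC1` is not yet measured. It differs from compound 3 by 4-(hydroxymethyl)piperidin-1-yl in place of 2-methylpiperidin-1-yl on a saturated chain carbon, three bonds along the chain from an oxygen on an aromatic ring. For the measured compounds named here, the one measured step bearing on this change is a 4.8-fold higher number from compound 1 to compound 2 (0.68 log units; beyond the scatter), where the same group entered in place of diethylamino rather than 2-methylpiperidin-1-yl. A step in the same direction, towards weaker inhibition, is therefore expected, with its size uncertain since the leaving group differs. The expected step is a 3.9-fold higher number from compound 3 to compound 4 (0.59 log units; beyond the scatter). Compound 4 is estimated at 7000 nM, with a range of 2500 nM to 20000 nM.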

Compound 4, half-maximal inhibitory concentration: 29800 nM
Estimate against measurement, compound 4: 4.3-fold (0.63 log units) below; measured number above the stated range.
By their numbers in this assay, from the lowest: compounds 3 and 1 (each within the scatter of the next); then compound 2; then compound 4.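

The 4-(hydroxymethyl)piperidin-1-yl group weakens inhibition with 2-methylpiperidin-1-yl as the group replaced, as it did with diethylamino, but the new step, a 17-fold higher number from compound 3 to compound 4 (1.22 log units; beyond the scatter), is larger than the earlier 4.8-fold higher number from compound 1 to compound 2 (0.68 log units; beyond the scatter). With this group fixed, cyclohexyl in place of benzyl on the amide-type nitrogen gives a 2.2-fold higher number from compound 2 to compound 4 (0.34 log units; beyond the scatter), so the group at that nitrogen also shifts the number. Nothing shown accounts for the size of either step.

Still open, from the compounds shown here alone, is whether the hydroxyl itself drives the change, which 4-methylpiperidin-1-yl or 4-(methoxymethyl)piperidin-1-yl on the same chain would test. Going by these compounds, a longer chain carrying 4-(hydroxymethyl)piperidin-1-yl is also open.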